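The source may report more compounds than this note shows. Statements on the series, on what has been measured and on what is new or still open speak of the compounds shown alone.

Compound 1 (`CN(C)CCCCCn1c2c(c3ccccc31)C(=O)c1c[n+]([O-])c3ccccc3c1C2=O`): 560 nM
Compound 2 (`CCCN1CCN(CCCCn2c3c(c4ccccc42)C(=O)c2c[n+]([O-])c4ccccc4c2C3=O)CC1`): 870 nM

In a functional assay on A-375 cells (Homo sapiens) for cytotoxicity, read by MTT assay, with a stated time of 72 h (on this read-out higher numbers stand for weaker inhibition and lower numbers for stronger inhibition), compound 2 stands level with compound 1, and the two values lie within the scatter of each other. Compound 3 (`O=C1c2c[n+]([O-])c3ccccc3c2C(=O)c2c1c1ccccc1n2CCN1CCCCC1`) has not yet been measured. Going from compound 2 to compound 3 is the change (piperidin-1-yl in place of 2-(4-propylpiperazin-1-yl)ethyl on a saturated chain carbon, two bonds along the chain from an aromatic nitrogen), with piperidin-1-yl in place of 2-(4-propylpiperazin-1-yl)ethyl on a saturated chain carbon, two bonds along the chain from an aromatic nitrogen. For the measured compounds named here, only one measured step bears on this: a 1.6-fold higher number from compound 1 to compound 2 (0.19 log units; within the scatter), where 4-propylpiperazin-1-yl replaced (dimethylamino)methyl on the chain. With that single precedent, no shift beyond the scatter is expected in this assay, and no direction can be favoured with confidence. The expected change is a 1.3-fold lower number from compound 2 to compound 3 (0.13 log units; within the scatter). Compound 3 is estimated at 650 nM, with an expected range from 220 nM to 1900 nM.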

Compound 3, half-maximal inhibitory concentration: 180 nM
Estimate against measurement, compound 3: 3.6-fold (0.56 log units) above; measured number below the stated range.
By their numbers in this assay, from the lowest: compound 3; then compounds 1 and 2 (each within the scatter of the next).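

In this assay, the position two bonds along the chain from an aromatic nitrogen yields its first steps beyond the scatter when piperidin-1-yl enters: a modest change in both cases (a 4.8-fold lower number from compound 2 to compound 3 (0.68 log units; beyond the scatter); a 3.1-fold lower number from compound 1 to compound 3 (0.49 log units; beyond the scatter)), which makes compound 3 the most potent of the three. The earlier pair had shown only a step within the scatter (a 1.6-fold higher number from compound 1 to compound 2 (0.19 log units; within the scatter)), so the side chain's outer part had not yet appeared to matter, and nothing at hand explains the new result.

Each step changes the chain and its end group together, so the compounds shown do not separate the two. They leave open whether piperidin-1-yl on a longer chain would keep this number, and whether a morpholine or pyrrolidine ring on the chain of compound 3 would match it.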